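This account rests on a few compounds, and the source may have more. Where it says the series, first, only, none or still open, it means among the compounds named here.

Measured so far:
- compound 1, `COc1ccc2c(c1)[n+]([O-])c(C(=O)N=[N+]=[N-])c(C)[n+]2[O-]`: 6.2%
- compound 2, `Cc1c(NC(=O)OC(C)C)[n+]([O-])c2cc(Cl)ccc2[n+]1[O-]`: 96.3%

Compound 2 stands at the top of these two numbers in a functional assay on Ehrlich cells (Mus musculus) for cytotoxicity, read by trypan blue exclusion, with a stated time of 2 h, tested at 50 ug/mL; on this read-out higher numbers stand for a weaker effect at the one concentration tested and lower numbers for a stronger effect. In this assay compound 2 gives 96.3%, whereas compound 1 gives 6.2%, a gap well beyond the scatter. The two compounds differ in more than one place, so nothing is known about what any single change does.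

Compound 3, `COc1ccc2c(c1)[n+]([O-])c(NC(=O)OC(C)C)c(C)[n+]2[O-]`, has not yet been tested. It keeps the core and the carbamate of compound 2 and changes only one thing: methoxy in place of chloro on an aromatic carbon. Going by the values given here, no measured pair shows the effect of this swap on its own. Compound 1 also carries a methoxy at this place but differs elsewhere as well, so it gives no clean reading of the step.

The step from compound 2 to compound 3 in this assay is expected to be small, perhaps slightly downward, a number 11.3 percentage points lower from compound 2 to compound 3 (beyond the scatter). Compound 3 is therefore estimated at 85%, within 55% to 100%.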

Compound 3, a percentage reported as activity, at one concentration (the size of the read-out at that concentration, not a potency): 76.2%
Compound 3: the middle estimate sits 8.8 percentage points above what was measured; the range from low to high includes it.
By their numbers in this assay, from the lowest: compound 1; then compound 3; then compound 2.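

In this assay, methoxy in place of chloro on an aromatic carbon, with nothing else changed, gives a number 20.1 percentage points lower from compound 2 to compound 3 (beyond the scatter), so this place on the ring does affect the read-out, and the effect of compound 3 is stronger than that of compound 2. With the methoxy held constant, the carbamate in place of the carbonyl azide gives a number 70 percentage points higher from compound 1 to compound 3 (beyond the scatter), so among these compounds the change at this second place has the larger effect. No measurement at hand explains either step.

The compounds shown leave open whether an amine or an ethoxy at the ring place would shift the number further. They also leave open whether the swap from chloro to methoxy would have a step of the same size with the carbonyl azide in place of the carbamate.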